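The source may hold more compounds than are shown below. What is called first, only, known or untested is meant among the compounds shown, and "the series" means these compounds.

Compound 1 `O=S(=O)(Nc1ccc(-c2nc3ccccc3o2)cc1)c1cccc(Cl)c1` gives in an ADME assay on HEK293 cells (Homo sapiens) for cytotoxicity, read by resazurin assay, with a stated time of 48 h; a higher number here means that more compound is tolerated, a lower number that less compound is tolerated > 100000 nM, which is a limit of the assay rather than a number. Compound 2 `COc1ccccc1S(=O)(=O)Nc1ccc2oc(-c3ccccc3)nc2c1` gives in this assay 41000 nM. Compound 3 `C=Cc1ccc(S(=O)(=O)Nc2ccc(-c3nc4ccccc4o3)cc2)cc1` gives in this assay > 100000 nM, again a limit of the assay.

Among these three, compound 2 stands as the only compound with an actual number; the other two values are limits. Among the measured compounds shown here, the one measured step between compounds differing in a single place is a step that the two limits leave unreadable from compound 1 to compound 3, and its size cannot be read because of the limit of > 100000 nM in this assay, at which 2 of the 3 values shown sit.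

The compound that follows is compound 4 `O=S(=O)(Nc1ccc2oc(-c3ccccc3)nc2c1)c1ccc(Cl)s1`. Compared with compound 2, the change is 5-chlorothiophen-2-yl in place of 2-methoxyphenyl on a sulfonyl sulfur. For the measured compounds named here, the only measured step also swaps the group on the sulfonyl sulfur, but since it runs between two limits it offers no readable size and no direction. Going by the values given here, no measured step therefore bears on this change in a way that can be quantified, and the expectation is that compound 4 stays near compound 2, with a wide margin on either side.

For the estimated step of a 1.1-fold higher number from compound 2 to compound 4 (0.04 log units; within the scatter), no change beyond the usual scatter is expected. Compound 4 is accordingly expected to give 45000 nM, within a range from 12000 nM to 100000 nM.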

Compound 4, half-maximal cytotoxic concentration: > 100000 nM
Compound 4: only a limit was reported (the forecaster's own chance of this, stated with the estimate: 40%); at least 2.2-fold (0.34 log units) between middle value and limit.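

Among the compounds shown here, on the sulfonyl sulfur of the core of compound 2, 5-chlorothiophen-2-yl in place of 2-methoxyphenyl gives the first readable step in this assay: an at least 2.4-fold higher number from compound 2 to compound 4 (0.38 log units; beyond the scatter). For the compounds shown here, this shows that the group at this place can shift the tolerated concentration by more than the usual scatter, which the unreadable step among the earlier compounds could not show. Compound 4 gives > 100000 nM, which is a limit of the assay and not a number, so the step has a known minimum but no known full size, for this reason: the limit of > 100000 nM in this assay, at which 3 of the 4 values shown sit.

The compounds shown leave open which part of the change matters, the loss of 2-methoxyphenyl or the arrival of 5-chlorothiophen-2-yl, and a plain thiophen-2-yl or plain phenyl on the same sulfur would separate the ring from its chlorine or methoxy group. Also open, as far as these compounds go, is whether a quite different group at this place, such as a short alkyl chain or a ring carrying an amine, would give a value that can be read as a number in this assay.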